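The source may hold more compounds than are shown below. What is called first, only, known or untested is meant among the compounds shown, and "the series" means these compounds.

In a functional assay on Huh-7 cells (Homo sapiens), read by fluorescence and BrdU incorporation, with a stated time of 48 h, tested at 25 uM (on this read-out lower numbers stand for a stronger effect and higher numbers for a weaker effect at the one concentration tested), compound 1 `COc1cc(OC)c(C(=O)/C=C/c2ccc(Cl)cc2)c(OC)c1` gives 0.8%, the smaller of the two numbers available, though the gap to its nearest neighbour lies within the scatter. Compound 2 `COc1cccc(/C=C/C(=O)c2c(O)cc(OC)cc2OC)c1` gives 8.5% in this assay, so the two cannot be told apart. Compound 3 `COc1cc(OC)c(C(=O)/C=C/c2ccccc2)c(OC)c1` has not yet been measured; it differs from compound 1 in one place: hydrogen in place of chloro on an aromatic carbon. Among the compounds with values here, no measured pair shows this change, so the step is only expected: a number 11.2 percentage points higher from compound 1 to compound 3 (beyond the scatter), toward a somewhat weaker effect, barely beyond the scatter. Compound 3 is expected to give about 12%, within a range from 0% to 45%.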

Compound 3, a percentage reported as activity, at one concentration (the size of the read-out at that concentration, not a potency): 0.7%
Compound 3: the middle estimate sits 11.3 percentage points above what was measured, and the stated range covers the measured number.
By their numbers in this assay, from the lowest: compounds 3, 1 and 2 (each within the scatter of the next).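

In this assay, within the data shown here, hydrogen in place of chloro on an aromatic carbon, para to a large group, gives a first reading for this change: a number 0.1 percentage points lower from compound 1 to compound 3 (within the scatter). The 4-chlorophenyl to phenyl change thus leaves the read-out unmoved at this position, so the chloro is not needed for the low number seen at the one concentration tested. No measurement in hand offers an explanation for this. Going by these compounds, whether an amine or a carboxylic acid at this same position would also leave the read-out unmoved stays open. A single concentration also leaves open any difference in potency between these compounds.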